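Swapping a Phenylethylamine Arm for a Branched Alkenyl Chain

A few compounds are considered here, and "the series" means these few. Any claim that something is new, unique, unknown or untested is made for them only; others in the source may bear on it.

Of the compounds shown here, three sharing one core have been measured in an assay on CHO cells for displacement of a labelled ligand from 5-hydroxytryptamine receptor 1D (Homo sapiens); a lower number here means a stronger inhibitor, a higher number a weaker inhibitor. Compound 1 `CN(CC1CCN(CCCc2c[nH]c3ccc(-n4cnnc4)cc23)CC1)C(=O)Nc1ccccc1` gives 5.9 nM in this assay. Compound 2 `C[C@@H](NCC1CCN(CCCc2c[nH]c3ccc(-n4cnnc4)cc23)CC1)c1ccccc1` gives 1.4 nM in this assay, and compound 3 `c1ccc(C2CCCCN2C2CCN(CCCc3c[nH]c4ccc(-n5cnnc5)cc34)CC2)cc1` gives 1.9 nM. Compound 2 has the lowest number of the three; its gap to compound 3 is within the scatter, while the step of a 4.2-fold lower number from compound 1 to compound 2 (0.62 log units; beyond the scatter) lies beyond it. Compound 4 `CC(C)=CCCN(C)C1CCN(CCCc2c[nH]c3ccc(-n4cnnc4)cc23)CC1` is not yet measured. It differs from compound 2 in one place: methyl(4-methylpent-3-en-1-yl)amino in place of ((1-phenylethyl)amino)methyl on a saturated ring carbon. Within the data shown here, the only measured step that bears on this is a 4.2-fold lower number from compound 1 to compound 2 (0.62 log units; beyond the scatter), and it altered the group on the chain carbon while keeping an aromatic ring in all three measured compounds; no measured pair shows what removing that ring and the hydrogen-bond donor does. A moderate rise in the number is therefore expected rather than a sharp loss. Compound 4 is expected to give about 10 nM in this assay, with a likely range from 2.5 nM to 40 nM. This estimate corresponds to an expected step of a 7.1-fold higher number from compound 2 to compound 4 (0.85 log units; beyond the scatter).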

Compound 4, half-maximal inhibitory concentration: 2.6 nM
For compound 4 the middle estimate is 3.8-fold (0.59 log units) above the measured one; measured number inside the range.
By their numbers in this assay, from the lowest: compounds 2, 3 and 4 (each within the scatter of the next); then compound 1.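

In this assay, the step of a 1.9-fold higher number from compound 2 to compound 4 (0.27 log units; within the scatter) shows that this saturated ring carbon can carry a group with no ring at all. Among these compounds, all the earlier compounds kept an aromatic ring in this part of the molecule, so they could not show this. Here the six-membered aromatic ring of carbon only, the hydrogen-bond donor and the defined stereocentre all leave together, and methyl(4-methylpent-3-en-1-yl)amino enters, yet the numbers stay within the scatter of each other; no measurement available here explains why.

Because these features changed in a single exchange, their separate contributions cannot be told apart. Going by these compounds, it also remains open whether the double bond matters, which a saturated 4-methylpentyl chain would test, and how a carboxylic acid at the end of the chain would fare.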